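A few compounds are considered here, and "the series" means these few. Any claim that something is new, unique, unknown or untested is made for them only; others in the source may bear on it.

Measured so far:
compound 1 `CC(CCc1cccc(OCc2ccc3ccccc3n2)c1)Cc1nnn[nH]1` – 17 nM
compound 2 `CC(CCc1ccc(OCc2ccc3ccccc3n2)cc1)Cc1nnn[nH]1` – 25 nM

Both were tested in an assay on membranes from lung (Cavia porcellus) for binding affinity to cysteinyl leukotriene receptor (Homo sapiens); a higher number here means a weaker inhibitor, a lower number a stronger inhibitor. Compound 2 has the higher of the two numbers, but its nearest neighbour, compound 1, lies within the usual scatter, so the two cannot be told apart. Compound 3 `O=C(O)CC1CCCC1Cc1ccc(OCc2ccc3ccccc3n2)cc1` is not yet measured. It differs from compound 2 in one place: 2-(carboxymethyl)cyclopentyl in place of 2-((1H-tetrazol-5-yl)methyl)propyl on a saturated chain carbon bound to an aromatic carbon. For the measured compounds named here, no measured pair shows this change, so its size is uncertain; a small step toward a higher number, at the edge of the scatter, is expected. For compound 3 the expected step is a 1.6-fold higher number from compound 2 to compound 3 (0.20 log units; within the scatter). Compound 3 is expected to give 40 nM, with a range from 10 nM to 160 nM.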

Compound 3, inhibition constant: 100 nM
Compound 3: middle estimate off by 2.5-fold (0.40 log units), on the low side, within the range that was stated.
By their numbers in this assay, from the lowest: compounds 1 and 2 (each within the scatter of the next); then compound 3.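

In this assay, the group at this position matters: replacing 2-((1H-tetrazol-5-yl)methyl)propyl with 2-(carboxymethyl)cyclopentyl gives a 4.0-fold higher number from compound 2 to compound 3 (0.60 log units; beyond the scatter), a modest loss of affinity. This single swap changes both the five-membered aromatic ring with its hetero atoms and the open chain, so the step belongs to the whole group, not to either part. Nothing available explains the step. The compounds shown leave open which part matters more. A 2-(carboxymethyl)propyl group or a 2-((1H-tetrazol-5-yl)methyl)cyclopentyl group would separate the two.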